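This account rests on a few compounds, and the source may have more. Where it says the series, first, only, none or still open, it means among the compounds named here.

Measured so far in an ADME assay on microsomes from liver (Rattus norvegicus) for metabolic stability, with a stated time of 10 min; a higher number here means that more of the compound is left, a lower number that less of the compound is left:
compound 1 `COc1cc(OCc2cccc(CCc3ccccc3)c2)c2cc(-c3cn4nc(OC)sc4n3)oc2c1` — 68%
compound 2 `COc1cc(OCc2cccc(C#N)c2)c2cc(-c3cn4nc(OC)sc4n3)oc2c1` — "not determined" (no result reported)
compound 3 `COc1cc(OCc2cccc(Sc3ccccc3)c2)c2cc(-c3cn4nc(OC)sc4n3)oc2c1` — 45%

In this assay, within the data shown here, compound 1 gives 68% and compound 3 gives 45%; the step between them, a number 23 percentage points lower from compound 1 to compound 3 (beyond the scatter), is the only measured step in the set. For compound 2 the result reads "not determined" (no result reported), so compound 2 stands on no number at all. Compound 4 `COc1cc(OCc2ccccc2OC)c2cc(-c3cn4nc(OC)sc4n3)oc2c1` differs from compound 2 in that (2-methoxyphenyl in place of 3-cyanophenyl on a saturated chain carbon bound to an oxygen on an aromatic ring). Neither compound 2 nor the 2-methoxyphenyl group appears in any measured step, so the step from compound 1 to compound 3 bears only indirectly on this change, and no direction beyond the scatter can be read from it. Compound 4 is therefore expected, as a plain estimate, at 55%, within 30% to 80%.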

Compound 4, percent of the compound remaining: 28%
Estimate against measurement, compound 4: 27 percentage points above; measured number outside the range, below it.
By their numbers in this assay, from the lowest: compound 4; then compound 3; then compound 1.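

In this assay compound 4 gives 28% but compound 2, which differs from it in one place, has no number, so no new step can be read. No evidence bears on this result. How 3-cyanophenyl and 2-methoxyphenyl compare in this assay stays open in the compounds shown.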